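The source may hold more compounds than are shown below. What is called first, only, known or untested is meant among the compounds shown, and "the series" means these compounds.

Working notes on a small sulfonamide series. Compound 1 `O=S(=O)(Nc1ccc(-c2nc3ccccc3o2)cc1)c1cccc(F)c1` carries a 3-fluorophenyl on the sulfonyl sulfur; in an assay on cells for inhibition of HSP60/HSP10 (Homo sapiens), with a stated time of 60 min (a lower number here means a stronger inhibitor, a higher number a weaker inhibitor), compound 1 gives 71000 nM. Compound 2 `O=S(=O)(Nc1ccc2oc(-c3ccccc3)nc2c1)c1cccc(O)c1` is a different arrangement of the same kind of sulfonamide and in this assay compound 2 gives 76000 nM. The two numbers lie within the scatter of each other, so neither compound can be set apart from the other; compound 1 simply sits at one end of a pair of values that read as equal.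

Compound 3 `O=S(=O)(Nc1ccc(-c2nc3ccccc3o2)cc1)c1ccc(F)cc1` is the next compound to be measured. It differs from compound 1 in one place only: 4-fluorophenyl in place of 3-fluorophenyl on a sulfonyl sulfur. The same atoms are present and only the point at which the fluorine sits on the ring moves. Going by the values given here, no measured pair of this kind is available, so the size of such a step is unknown here. The expectation is a step from compound 1 to compound 3 of a 1.0-fold lower number from compound 1 to compound 3 (0.01 log units; within the scatter), which is taken as no change beyond the scatter, in either direction. Compound 3 is thus expected to give about 70000 nM in this assay, within a range from 30000 nM to 160000 nM.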

Compound 3, half-maximal inhibitory concentration: 73000 nM
Beside the measured number, compound 3's estimate is 1.0-fold (0.02 log units) below it; the measured number falls inside the stated range.
By their numbers in this assay, from the lowest: compounds 1, 3 and 2 (each within the scatter of the next).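

Moving the fluorine, with 4-fluorophenyl in place of 3-fluorophenyl on a sulfonyl sulfur, gives in this assay a 1.0-fold higher number from compound 1 to compound 3 (0.01 log units; within the scatter), and this lies within the scatter. Going by these compounds alone, this is the only step so far that changes one place alone, so it gives the first direct reading at this position. The earlier pair could not provide such a reading. Those two compounds differ in more than one place. On this reading the two fluorophenyl arrangements cannot be told apart in this assay, although a single pair says nothing about any other change at the sulfonyl sulfur. Nothing at hand bears on why the two arrangements read alike.

Still open, from the compounds shown here alone, is whether this position responds to anything beyond a shift of the fluorine on the ring, for instance a phenyl carrying a carboxylic acid or an amine, or a longer chain in place of the ring, with the core of compound 1 kept unchanged. Also open, going by these compounds, is whether any single change to that core itself, such as a methoxy group on its rings, would produce a step beyond the scatter.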